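The source may report more compounds than this note shows. Statements on the series, on what has been measured and on what is new or still open speak of the compounds shown alone.

Compound 1 `COc1cc(-c2cccc3nc(-c4ccccc4)oc23)cc(OC)c1OC`: > 25000 nM
Compound 2 `COc1ccc(-c2nc3cccc(-c4cc(OC)c(OC)c(OC)c4)c3o2)cc1`: > 25000 nM
Compound 3 `COc1cc(-c2cccc3nc(-c4cccc(Br)c4)oc23)cc(OC)c1OC`: > 25000 nM

All three entries come from a functional assay on MCF7 cells (Homo sapiens) for antiproliferative activity, read by MTT assay, with a stated time of 48 h (on this read-out lower numbers stand for stronger inhibition and higher numbers for weaker inhibition), and each is a limit rather than a number. For the measured compounds named here, the whole series so far shares one reading: the limit of > 25000 nM in this assay, at which 3 of the 3 values shown sit. In this assay compound 3 gives > 25000 nM, which is a limit, so its true position is not known.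

The next compound, compound 4 `COc1cc(-c2cccc3nc(-c4cccc(Cl)c4)oc23)cc(OC)c1OC`, has chloro in place of bromo on an aromatic carbon, meta to a large group, turning 3-bromophenyl into 3-chlorophenyl: chloro in place of bromo on an aromatic carbon. The closest measured guide is a step that the two limits leave unreadable from compound 1 to compound 3, where bromo replaces hydrogen on the same kind of carbon. Two further steps also touch this part of the series: a step that the two limits leave unreadable from compound 2 to compound 3 and a step that the two limits leave unreadable from compound 1 to compound 2. None of the three has a readable size, so no measured size can be carried over to the new change. Going by the values given here, nothing measured so far suggests that swapping one halogen for another would bring the read-out clear of the limit.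

The step expected in this assay is a step that the limit leaves unreadable from compound 3 to compound 4, and the data support no direction for it. For compound 4 the estimated value is 30000 nM, with an expected range from 12000 nM to 60000 nM.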

Compound 4, half-maximal inhibitory concentration: > 25000 nM
Compound 4: a limit, no number (the forecaster's own chance of this, stated with the estimate: 80%); the middle value lies beyond the limit too.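

Compound 4, like compound 1, compound 2 and compound 3, gives a limit rather than a number, so none of the steps linking compound 4 to those three can be read: the limit of > 25000 nM in this assay, at which 4 of the 4 values shown sit. The compounds shown leave open how far past that limit each one truly lies, and whether the groups that differ among them change the read-out at all.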